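The compounds below may be only part of what the source reports. "The series", "measured", "known", "first", "only" and "open" are said of these compounds alone.

Compound 1 `O=C(CCc1cn(Cc2ccc3oc(-c4ccccc4)cc(=O)c3c2)nn1)Nc1ccc(Cl)cc1` is one of three measured compounds built on a shared core. In an assay on isolated protein for inhibition of Amine oxidase [flavin-containing] B (Homo sapiens), read by fluorescence and spectrophotometry (a higher number here means a weaker inhibitor, a lower number a stronger inhibitor), compound 1 gives 15600 nM. Compound 2 `O=C(CCCCc1cn(Cc2ccc3oc(-c4ccccc4)cc(=O)c3c2)nn1)Nc1ccccc1` gives 15600 nM in this assay, and compound 3 `O=C(CCCCc1cn(Cc2ccc3oc(-c4ccccc4)cc(=O)c3c2)nn1)Nc1ccc(F)cc1` gives 15600 nM in this assay. Compound 1 therefore stands level with both of its neighbours: the step of no change at the digits printed from compound 1 to compound 2 (within the scatter) and the step of no change at the digits printed from compound 1 to compound 3 (within the scatter) both lie within the scatter of repeated measurements, as does the step of no change at the digits printed from compound 2 to compound 3 (within the scatter) between the other two.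

The unmeasured compound 4 `O=C(CCc1cn(Cc2ccc3oc(-c4ccc(Cl)cc4)cc(=O)c3c2)nn1)Nc1ccc(Cl)cc1` differs from compound 1 by a single change, (chloro in place of hydrogen on an aromatic carbon). Within the data shown here, none of the measured steps touches this exact spot on the shared core. Among the measured compounds shown here, the only measured step that swaps a halogen for a hydrogen on an aromatic carbon is the one from compound 2 to compound 3, and that step brought no change beyond the scatter in this assay. For the measured compounds named here, nothing measured so far suggests that a halogen placed on an aromatic carbon moves the read-out in this assay.

On that basis the step from compound 1 to compound 4 is expected to be no change at the digits printed from compound 1 to compound 4 (within the scatter), that is, no shift beyond the scatter. For compound 4 the estimated value in this assay is 15600 nM, with a likely range from 7000 nM to 35000 nM.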

Compound 4, half-maximal inhibitory concentration: 32900 nM
Compound 4: the middle estimate sits 2.1-fold (0.32 log units) below what was measured; measured number inside the range.
By their numbers in this assay, from the lowest: compounds 1, 2 and 3 (each within the scatter of the next); then compound 4.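

Among these compounds, this is the first change at this spot on the shared core that moves the number beyond the scatter: in this assay, going from phenyl to 4-chlorophenyl gives a 2.1-fold higher number from compound 1 to compound 4 (0.32 log units; beyond the scatter), a modest loss of inhibition. The only other swap of a halogen for a hydrogen shown here, fluoro on an aromatic carbon elsewhere in the molecule, gives no change at the digits printed from compound 2 to compound 3 (within the scatter), so a halogen on an aromatic carbon does not always leave this read-out unchanged, although these two steps differ in both the halogen and the site. Nothing available here accounts for the weaker inhibition seen with this chloro group.

What the compounds shown leave open is whether the loss belongs to chloro itself or would also appear with fluoro, methoxy, an amine or a carboxylic acid at the same carbon. From the compounds shown here alone, it also remains open whether the same change would have a similar effect on the longer chain carried by compound 2, or whether a group placed elsewhere on this phenyl ring would give stronger inhibition.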